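Lengthening the chain between the cyclobutane and the piperazine

The source may hold more compounds than are shown below. What is called first, only, known or untested is meant among the compounds shown, and "the series" means these compounds.

Three compounds were tested in a functional assay on the whole organism for antagonist activity, with Rattus norvegicus as the target; on this read-out higher numbers stand for an effect only at larger amounts of compound and lower numbers for an effect already at smaller amounts. Compound 1 `c1ccc2c(c1)CC2CCCCN1CCN(c2cccc3c2OCCO3)CC1` gives 5 mg/kg, compound 2 `COc1cc2c(cc1OC)C(CCN1CCN(c3cccc4c3OCCO4)CC1)CC2` gives 2.5 mg/kg, and compound 3 `c1ccc2c(c1)CC2CN1CCN(c2cccc3c2OCCCO3)CC1` gives 0.63 mg/kg. Compound 3 thus holds the lowest number of the three; its gap to compound 2 and the wider gap to compound 1 both lie beyond the usual scatter. Compound 4 `c1ccc2c(c1)CC2CCN1CCN(c2cccc3c2OCCCO3)CC1` has not yet been measured. It differs from compound 3 in one place: a group of 9 heavy atoms (9 carbon; one four-membered non-aromatic ring of carbon only, one six-membered aromatic ring of carbon only) in place of a group of 8 heavy atoms (8 carbon; one four-membered non-aromatic ring of carbon only, one six-membered aromatic ring of carbon only), on a saturated chain carbon bound to an amine nitrogen in a ring. For the measured compounds named here, no measured pair shows a step of this kind, so the expectation rests on compound 3 alone and is guarded. Compound 4 is expected to give 1.25 mg/kg, between 0.4 mg/kg and 4 mg/kg, and the estimated step of a 2.0-fold higher number from compound 3 to compound 4 (0.30 log units; within the scatter) would be a small rise in this assay, near the edge of the scatter.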

Compound 4, minimum effective dose: 1.25 mg/kg
Compound 4: the middle estimate sits on the measured number at the digits printed; the range from low to high includes it.
By their numbers in this assay, from the lowest: compounds 3, 4, 2 and 1 (each within the scatter of the next, the first and the last beyond it).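

In this assay, for the compounds shown here, the only pair differing in one place gives a 2.0-fold higher number from compound 3 to compound 4 (0.30 log units; within the scatter), so a group of 9 heavy atoms in place of a group of 8 heavy atoms, on a saturated chain carbon bound to an amine nitrogen in a ring, leaves no shift distinguishable from the scatter. Compound 1 and compound 2 each differ from compound 3 in more than one place and could not show this. Nothing available explains the result. On these data alone, whether a longer chain on the same core would also stay within the scatter remains open, as does the effect of a hydroxyl group on that chain.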